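The compounds below may be only part of what the source reports. "The series", "measured", "known", "first", "only" and "open" are said of these compounds alone.

Three compounds built on a shared core, that of compound 1 `CNC(=O)c1c(O)c2cccnc2n(-c2ccccc2)c1=O`, have been measured in a functional assay on the whole organism for inhibition, with Rattus norvegicus as the target, read by paw edema, at a dose of 100 mg/kg by the oral route; on this read-out higher numbers stand for more inhibition at the one dose given (going by the name of the read-out) and lower numbers for less inhibition. Compound 1 gives 9.6%. Compound 2 `CCCCNC(=O)c1c(O)c2cccnc2n(-c2ccccc2)c1=O` gives 12.8%, and the step of a number 3.2 percentage points higher from compound 1 to compound 2 (within the scatter) lies within the scatter, so the two cannot be ordered. Compound 3 `O=C(Nc1cccnc1)c1c(O)c2cccnc2n(-c2ccccc2)c1=O` gives 30.3%, the highest of the three, with compound 2 nearest and compound 1 furthest; the steps of a number 20.7 percentage points higher from compound 1 to compound 3 (beyond the scatter) and a number 17.5 percentage points higher from compound 2 to compound 3 (beyond the scatter) are both modest and both beyond the scatter.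

Compound 4 `O=C(Nc1ccncc1)c1c(O)c2cccnc2n(-c2ccccc2)c1=O` is next, differing from compound 3 by pyridin-4-yl in place of pyridin-3-yl on an amide-type nitrogen. Among the measured compounds shown here, no measured step moves the ring nitrogen from one position to another; the two steps that bear on the change, from compound 1 and from compound 2 to compound 3, only show that a pyridin-3-yl group on the amide-type nitrogen gave a modest rise over methyl and over butyl. A pyridin-4-yl group keeps the same atoms in a ring of the same kind, so compound 4 is expected to sit close to compound 3, with a step of a number 2.3 percentage points lower from compound 3 to compound 4 (within the scatter) that should not exceed the scatter. Compound 4 is therefore estimated at 28%, within a range from 12% to 45%.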

Compound 4, a percentage reported as inhibition, in the whole organism at one dose (the size of the read-out at that dose, not a potency): 34.9%
Compound 4: middle estimate off by 6.9 percentage points, on the low side, within the range that was stated.
By their numbers in this assay, from the lowest: compounds 1 and 2 (each within the scatter of the next); then compounds 3 and 4 (each within the scatter of the next).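

Exchanging pyridin-3-yl for pyridin-4-yl on an amide-type nitrogen, with the same atoms joined differently, gives a step of a number 4.6 percentage points higher from compound 3 to compound 4 (within the scatter) in this assay and so leaves the two compounds unordered; at this one dose, the change of ring attachment does not separate them. The rise over the simple chains now appears with a second pyridinyl group, as a number 22.1 percentage points higher from compound 2 to compound 4 (beyond the scatter) and a number 25.3 percentage points higher from compound 1 to compound 4 (beyond the scatter) are both modest, so the gain over butyl and methyl is not confined to pyridin-3-yl. No measurement in hand bears on why the two pyridinyl groups read alike or why they stand apart from methyl and butyl.

The compounds shown leave open whether pyridin-2-yl or a plain phenyl ring on the same amide-type nitrogen would fall with the two pyridinyl compounds or with the methyl and butyl compounds, and hence whether the ring nitrogen matters at all. They also leave open what a longer chain ending in an amine or a carboxylic acid would do at this position, and a single dose says nothing about how the response changes with dose.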